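An amino group added to compound 3

The source may hold more compounds than are shown below. What is called first, only, known or untested is meant among the compounds shown, and "the series" means these compounds.

In a functional assay on KB cells (Homo sapiens) for antiproliferative activity, read by MTT assay, with a stated time of 72 h (a lower number here means a stronger inhibitor, a higher number a weaker inhibitor), compound 3 `COc1ccc(-c2c(-c3cc(OC)c(OC)c(OC)c3)ssc2=S)cc1` gives 1140 nM as the higher of the two actual numbers in the series. Compound 1 `COc1ccc(-c2ssc(=S)c2-c2cc(OC)c(OC)c(OC)c2)cc1O` gives 435 nM as the lower one, a gap beyond the scatter. Compound 2 `COc1ccc(-c2ssc(=S)c2-c2cc(OC)c(OC)c(OC)c2)cc1[N+](=O)[O-]` gives > 100000 nM which is a limit of the assay. Compound 4 `COc1ccc(-c2c(-c3cc(OC)c(OC)c(OC)c3)ssc2=S)cc1N` has amino in place of hydrogen on an aromatic carbon and this amino sits ortho to a methoxy group. For the measured compounds named here, one measured step bears on this change, and only indirectly: nitro in place of hydroxy on an aromatic carbon gives an at least 220-fold higher number from compound 1 to compound 2 (2.36 log units; beyond the scatter) and is large. It shows that the group at that place can matter, but compound 1 and compound 2 differ from compound 3 in more than this group. Compound 1 with its hydroxy gives 435 nM and is taken as the closer guide, so a modest move to a lower number is expected. In this assay the expected change is a 3.3-fold lower number from compound 3 to compound 4 (0.51 log units; beyond the scatter) by this estimate. For compound 4 the estimate is 350 nM with an expected range from 70 nM to 1800 nM as its span.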

Compound 4, half-maximal inhibitory concentration: 2170 nM
Compound 4: middle estimate off by 6.2-fold (0.79 log units), on the low side; measured number above the stated range.
By their numbers in this assay, from the lowest: compound 1; then compounds 3 and 4 (each within the scatter of the next). At a limit, above all of these: compound 2.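

The step reads a 1.9-fold higher number from compound 3 to compound 4 (0.28 log units; within the scatter) in this assay, so with the shared core of compound 3 and compound 4, amino and hydrogen on this aromatic carbon, ortho to a methoxy group, cannot be told apart. The earlier compounds had shown only that nitro in place of hydroxy on the core of compound 1 gives a large step, so this is the first sign that a group can be added at this place with no change beyond the scatter. Nothing measured here gives a reason for this result.

From the compounds shown here alone, it remains open whether hydroxy or nitro at this place on the core of compound 3 would give a large step too. Going by these compounds, what a larger group here, such as a dimethylamino group, an acetamide or a carboxylic acid, would give also remains open.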